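A few compounds are considered here, and "the series" means these few. Any claim that something is new, unique, unknown or untested is made for them only; others in the source may bear on it.

Compound 1 `Cc1ccc2nc(/N=C3\C(=O)N(CN4CCCCC4)c4ccccc43)sc2c1`: 65600 nM
Compound 2 `O=C1C(=O)N(CN2CCCCC2)c2cccc(Br)c21`: 35300 nM

In a functional assay on MDA-MB-468 cells (Homo sapiens) for cytotoxicity, read by sulforhodamine B assay, with a stated time of 48 h (on this read-out higher numbers stand for weaker inhibition of growth and lower numbers for stronger inhibition of growth), compound 1 gives 65600 nM, the higher number of the two, although the gap to compound 2, which gives 35300 nM, lies within the usual scatter. Compound 3 `Cc1ccc2nc(/N=C3\C(=O)N(CN4CCCCC4)c4cccc(Cl)c43)sc2c1` has not been measured in this assay. It differs from compound 1 by chloro in place of hydrogen on an aromatic carbon. Among the measured compounds shown here, no measured pair shows this change, so the step in this assay is expected to be a 1.3-fold lower number from compound 1 to compound 3 (0.12 log units; within the scatter), with no direction beyond the scatter. Compound 3 is estimated at 50000 nM, in a range from 18000 nM to 140000 nM.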

Compound 3, concentration for 50% growth inhibition: 19800 nM
Compound 3: the middle estimate sits 2.5-fold (0.40 log units) above what was measured, and the stated range covers the measured number.
By their numbers in this assay, from the lowest: compounds 3, 2 and 1 (each within the scatter of the next, the first and the last beyond it).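

In this assay, among the compounds shown here, chloro in place of hydrogen on an aromatic carbon of the shared core produces the first step here that lies beyond the scatter (a 3.3-fold lower number from compound 1 to compound 3 (0.52 log units; beyond the scatter)), though a modest one. This shows that growth inhibition responds to a single chlorine atom at this position on the six-membered aromatic ring of carbon only. No available evidence bears on the reason for this step. Going by these compounds, whether fluoro, methoxy or an amine at this position would move the number in the same direction remains open.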